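Methoxy in Place of Methyl on the Aryl Ring of Compound 1

The source may report more compounds than this note shows. Statements on the series, on what has been measured and on what is new or still open speak of the compounds shown alone.

Compound 1 `Cc1cccc(-n2c(C)cc(C(=O)O)c2C)c1` gives 1500 nM in an assay on cells for inhibition of Palmitoleoyl-protein carboxylesterase NOTUM variant C330S (Homo sapiens), read by fluorescence, with a stated time of 40 min; on this read-out higher numbers stand for weaker inhibition and lower numbers for stronger inhibition.
Compound 2 `Cc1cc(C(=O)O)c(C)n1-c1ccccc1Cl` gives 2300 nM in this assay.
Compound 3 `Cc1cc(C(=O)O)c(C)n1-c1ccc(Cl)cc1` gives 860 nM in this assay.

Of the compounds shown here, three on the shared core have been measured so far, and all three carry a single substituent on the phenyl ring attached to the nitrogen. Compound 1 stands second highest of the three numbers in this assay. Its nearest neighbour is compound 2, whose number is higher, and the furthest is compound 3, whose number is lower; both of these gaps lie within the usual scatter of the assay, so the three compounds cannot be ordered against each other on present data.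

Compound 4 `COc1cccc(-n2c(C)cc(C(=O)O)c2C)c1` is the next compound to be measured. It differs from compound 1 in one place: methoxy in place of methyl on an aromatic carbon. Among the compounds with values here, no pair of measured compounds shows the size of such a step, so the expectation rests on the narrow spread of the three known values. The step from compound 1 to compound 4 is expected to be no change at the digits printed from compound 1 to compound 4 (within the scatter), no larger than the scatter, in either direction. Compound 4 is therefore estimated at 1500 nM, with a range from 600 nM to 4000 nM.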

Compound 4, half-maximal inhibitory concentration: 1500 nM
Compound 4: middle estimate and measured number agree at the digits printed; low and high end bracket the measured number.
By their numbers in this assay, from the lowest: compounds 3, 1, 4 and 2 (each within the scatter of the next, the first and the last beyond it).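

In this assay, within the data shown here, methoxy in place of methyl on an aromatic carbon, meta to a large group, gives no change at the digits printed from compound 1 to compound 4 (within the scatter), the first step in this set that changes one place only. The earlier compounds shown here could be set side by side only as a loose spread of values, whereas this pair isolates a single change and shows that the number can stay put when the substituent grows from one heavy atom to two and gains an oxygen and a hydrogen-bond acceptor. Nothing measured with these compounds explains why the number holds at this position, so the result stands as an observation only.

The compounds shown leave open whether an amine, a hydroxy group or a longer chain such as propoxy on this same aromatic carbon would also leave the number in place, or would move it beyond the scatter. They also leave open whether methoxy would behave the same way elsewhere on the six-membered ring, and whether the carboxylic acid of the shared core could give way to a primary amide.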